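This account rests on a few compounds, and the source may have more. Where it says the series, first, only, none or still open, it means among the compounds named here.

Measured so far in a functional assay on SMMC-7721 cells (Homo sapiens) for cytotoxicity, read by MTT assay, with a stated time of 48 h; on this read-out lower numbers stand for stronger inhibition and higher numbers for weaker inhibition:
- compound 1 `CN(C)Cc1cc(Cl)cc2c(=O)cc(-c3ccc([N+](=O)[O-])cc3)oc12` gives 56500 nM
- compound 2 `O=c1cc(-c2ccc([N+](=O)[O-])cc2)oc2c(Cn3ccnc3)cc(Cl)cc12` gives 1200 nM

Compound 2 has the lower of the two numbers, and the gap between them lies beyond the scatter. Compound 3 `O=c1cc(-c2ccccc2Cl)oc2c(Cn3ccnc3)cc(Cl)cc12` differs from compound 2 in one place, where 2-chlorophenyl replaces 4-nitrophenyl on an aromatic carbon next to the ring oxygen: 2-chlorophenyl in place of 4-nitrophenyl on an aromatic carbon. Going by the values given here, the only measured step is large, a 47-fold lower number from compound 1 to compound 2 (1.67 log units; beyond the scatter), but it puts 1H-imidazol-1-yl in place of dimethylamino on a saturated chain carbon, not at this aromatic carbon. It bears on the new change only indirectly, showing that one exchange among these compounds can move the number widely. No measurement fixes the size or direction of the new change, so the expectation starts from compound 2 at 1200 nM and allows a wide margin, with a slight lean towards a higher number. The expected change is a 2.1-fold higher number from compound 2 to compound 3 (0.32 log units; beyond the scatter). In this assay compound 3 is estimated at 2500 nM, with an expected range from 500 nM to 13000 nM.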

Compound 3, half-maximal inhibitory concentration: 1070 nM
Compound 3: the middle estimate sits 2.3-fold (0.37 log units) above what was measured; low and high end bracket the measured number.
By their numbers in this assay, from the lowest: compounds 3 and 2 (each within the scatter of the next); then compound 1.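

In this assay, putting 2-chlorophenyl in place of 4-nitrophenyl on the aromatic carbon next to the ring oxygen gives a 1.1-fold lower number from compound 2 to compound 3 (0.05 log units; within the scatter), so this exchange leaves the number within the scatter while the 1H-imidazol-1-yl group stays in place. Going by these compounds alone, this is the first view of this aromatic carbon, and the contrast with the only earlier step, a 47-fold lower number from compound 1 to compound 2 (1.67 log units; beyond the scatter), is clear: that large step came from the saturated chain carbon, whereas these two different substituted phenyl groups cannot be told apart here. No available evidence bears on why the two phenyl groups read alike.

The exchange alters both the substituent on the phenyl ring and its place on that ring, so the compounds shown cannot say whether either alteration alone would leave the number unmoved, or whether the two happen to offset each other. On these data alone, it also remains open how an unsubstituted phenyl, or a phenyl carrying an amine or a carboxylic acid, would read at this carbon, and whether 2-chlorophenyl would behave the same way with dimethylamino on the chain carbon, as in compound 1.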